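A few compounds are considered here, and "the series" means these few. Any claim that something is new, unique, unknown or untested is made for them only; others in the source may bear on it.

Measured so far in a functional assay on HeLa cells (Homo sapiens) for cytotoxicity, read by WST assay, with a stated time of 48 h; on this read-out higher numbers stand for weaker inhibition and lower numbers for stronger inhibition:
- compound 1, `COC[C@H](C)[C@@H](C)C(c1ccc(O)c(OC)c1)c1ccc(O)c(OC)c1`: 77000 nM
- compound 3, `COc1cc(C(c2ccc(O)c(OC)c2)[C@H](CC(C)C)C(C)C)ccc1O`: 8200 nM
- compound 2, `COc1ccc(C(c2ccc(OC)c(OC)c2)[C@H](C)[C@H](C)CO)cc1OC`: gives only a limit of the assay, > 100000 nM

Compound 3 stands at the lowest of the two numbers shown, with compound 1 the nearest, its number higher by a 9.4-fold lower number from compound 1 to compound 3 (0.97 log units; beyond the scatter). Compound 4, `COc1cc(C(c2ccc(O)c(OC)c2)[C@H](C)[C@H](C)CO)ccc1O`, has not yet been measured. It differs from compound 3 in one place: 2-(hydroxymethyl)-1-methylpropyl in place of 1-isopropyl-3-methylbutyl on a saturated chain carbon bound to two aromatic carbons. For the measured compounds named here, the one measured step that bears on this change is the one in which 1-isopropyl-3-methylbutyl replaced 2-(methoxymethyl)-1-methylpropyl, giving a 9.4-fold lower number from compound 1 to compound 3 (0.97 log units; beyond the scatter). Compound 4 carries a chain of the same kind as compound 1, so a reversal of that step is expected, a higher number in this assay. Compound 2, which shares the 2-(hydroxymethyl)-1-methylpropyl chain, sits at the limit of > 100000 nM in this assay, at which 1 of the 3 values shown sits, and so gives no number to narrow this. Compound 4 is therefore expected to show a step of about a 9.8-fold higher number from compound 3 to compound 4 (0.99 log units; beyond the scatter). The estimate for compound 4 is 80000 nM, within a range from 30000 nM to 200000 nM.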

Compound 4, half-maximal inhibitory concentration: > 100000 nM
Compound 4 was reported as a limit (the forecaster's own chance of this, stated with the estimate: 30%); at least 1.2-fold (0.09 log units) between middle value and limit.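

With the core of compound 3 unchanged, putting 2-(hydroxymethyl)-1-methylpropyl in place of 1-isopropyl-3-methylbutyl on the saturated chain carbon bound to two aromatic carbons gives an at least 12-fold higher number from compound 3 to compound 4 (1.08 log units; beyond the scatter), so the chain at this position alone moves the number in this assay by a large step. The hydroxymethyl and methoxymethyl chain ends cannot be ordered, since the floor of an at least 1.2-fold higher number from compound 1 to compound 4 (0.11 log units; that floor lies within the scatter) lies within the scatter. Compound 4 gives only a limit, and it joins compound 2 there: the limit of > 100000 nM in this assay, at which 2 of the 4 values shown sit.

Going by these compounds, how far the true value of compound 4 lies past that limit stays unknown. Also open, on these data alone, is whether a longer all-carbon chain, or an amine at the chain end, would bring the number in this assay lower than that of compound 3.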